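This account rests on a few compounds, and the source may have more. Where it says the series, first, only, none or still open, it means among the compounds named here.

Measured in a toxicity assay on HepG2 2.2.15 cells (Homo sapiens) for cytotoxicity, read by CellTiter-Glo; on this read-out lower numbers stand for higher toxicity in this test and higher numbers for lower toxicity in this test:
Compound 1 `O=C1CC(Oc2ncccn2)CN1c1cnn2c1CN(C(=O)Nc1cc(F)c(F)c(F)c1)C(C1CC1)C2`: > 200000 nM
Compound 2 `Cc1cnc(C2CC(=O)N(c3cnn4c3CN(C(=O)Nc3cc(F)c(F)c(F)c3)C(C3CC3)C4)C2)s1`: 96200 nM
Compound 3 `O=C(Nc1cc(F)c(F)c(F)c1)N1Cc2c(-c3ccc(F)cc3)cnn2CC1C1CC1`: 38500 nM

The value for compound 1 is a limit of the assay and not a number. Of the two actual numbers, compound 3 holds the lower, and compound 2 is its nearest neighbour on this scale.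

The next compound, compound 4 `O=C1CC(c2nccs2)CN1c1cnn2c1CN(C(=O)Nc1cc(F)c(F)c(F)c1)C(C1CC1)C2`, carries 2-oxo-4-(1,3-thiazol-2-yl)pyrrolidin-1-yl in place of 4-fluorophenyl on an aromatic carbon of a five-membered aromatic ring with 2 nitrogen: 2-oxo-4-(1,3-thiazol-2-yl)pyrrolidin-1-yl in place of 4-fluorophenyl on an aromatic carbon.

The closest measured change runs the other way. It is a 2.5-fold lower number from compound 2 to compound 3 (0.40 log units; beyond the scatter), with 4-fluorophenyl in place of 4-(5-methyl-1,3-thiazol-2-yl)-2-oxopyrrolidin-1-yl. The other measured change, an at least 2.0-fold lower number from compound 1 to compound 2 (0.31 log units; beyond the scatter), shows that the substituent on the saturated ring carbon of the lactam-bearing compounds also shifts the reading. As far as these compounds go, it rests on (the limit of > 200000 nM in this assay, at which 1 of the 3 values shown sits), so its true size remains open.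

A modest move towards a higher number is therefore expected in this assay, roughly mirroring the step to compound 3, and the estimated change is a 2.9-fold higher number from compound 3 to compound 4 (0.46 log units; beyond the scatter). For compound 4 the expected value is 110000 nM, with an estimated range of 50000 nM to 230000 nM.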

Compound 4, half-maximal cytotoxic concentration: 115000 nM
Compound 4: the middle estimate sits 1.0-fold (0.02 log units) below what was measured, and the stated range covers the measured number.
By their numbers in this assay, from the lowest: compound 3; then compounds 2 and 4 (each within the scatter of the next). At a limit, above all of these: compound 1.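

In this assay, putting 2-oxo-4-(1,3-thiazol-2-yl)pyrrolidin-1-yl in place of 4-fluorophenyl on this aromatic carbon gives a 3.0-fold higher number from compound 3 to compound 4 (0.48 log units; beyond the scatter) and so shows this change directly, with a lactam whose thiazole carries no methyl. Hydrogen in place of methyl on the thiazole gives a 1.2-fold higher number from compound 2 to compound 4 (0.08 log units; within the scatter) and so leaves the two thiazole lactams reading alike, which means that the gap to the 4-fluorophenyl compound appears with or without that methyl. Compound 1 reads as a limit and not a number, and 1,3-thiazol-2-yl in place of (pyrimidin-2-yl)oxy on the saturated ring carbon gives an at least 1.7-fold lower number from compound 1 to compound 4 (0.24 log units; that floor lies within the scatter) and so does not settle how far these two groups differ: the limit of > 200000 nM in this assay, at which 1 of the 4 values shown sits.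

The compounds shown leave open how an amine or a carboxylic acid on that saturated ring carbon would read in this assay. They also leave open whether an unsubstituted phenyl on the aromatic carbon would read like the 4-fluorophenyl group or would move the number towards that of the lactams.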